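A fluorophenyl swap on compound 3

The compounds below may be only part of what the source reports. "The series", "measured", "known", "first", "only" and "open" are said of these compounds alone.

Values in an ADME assay on HUVEC cells (Homo sapiens) for inhibition, read by CCK-8 assay, with a stated time of 24 h, in the presence of a further agent that is not named here; on this read-out higher numbers stand for weaker inhibition and lower numbers for stronger inhibition:
- Compound 1 `Cc1cccc(-n2cc(-c3ccc(/C=C4\C(=O)Nc5ccccc54)cc3)nn2)c1`: 13700 nM
- Compound 2 `O=C1Nc2ccccc2/C1=C/c1ccc(-c2cn(-c3ccccc3Cl)nn2)cc1`: > 20000 nM (a limit of the assay, not a number)
- Compound 3 `Cc1cccc(-n2cc(-c3ccc(/C=C4\C(=O)Nc5ccc(F)cc54)cc3)nn2)c1`: 9880 nM

Only compound 1 and compound 3 have true numbers to compare. Compound 3 gives 9880 nM, which lies within the usual scatter of the result for compound 1, so these two cannot be ranked. Compound 4 `O=C1Nc2ccc(F)cc2/C1=C/c1ccc(-c2cn(-c3ccccc3F)nn2)cc1` has not yet been measured. The change from compound 3 to compound 4 is 2-fluorophenyl in place of 3-methylphenyl on an aromatic nitrogen.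

The closest guide is an at least 1.4-fold higher number from compound 1 to compound 2 (0.16 log units; that floor lies within the scatter), which also replaces 3-methylphenyl, in that case with 2-chlorophenyl. The size of that step is only a floor, since it rests on a limit. The other measured step, a 1.4-fold lower number from compound 1 to compound 3 (0.14 log units; within the scatter), adds a fluoro in place of hydrogen on an aromatic carbon. Compound 3 and compound 4 both carry that fluoro, so this step does not separate them.

In this assay, a small move towards a higher number is therefore expected, with an estimated 1.4-fold higher number from compound 3 to compound 4 (0.15 log units; within the scatter). For compound 4 the estimate is 14000 nM, with an expected range from 6500 nM to 20000 nM.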

Compound 4, half-maximal inhibitory concentration: 14400 nM
Estimate against measurement, compound 4: 1.0-fold (0.01 log units) below; low and high end bracket the measured number.
By their numbers in this assay, from the lowest: compounds 3, 1 and 4 (each within the scatter of the next). At a limit, above all of these: compound 2.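

In this assay, putting 2-fluorophenyl in place of 3-methylphenyl on the aromatic nitrogen gives a 1.5-fold higher number from compound 3 to compound 4 (0.16 log units; within the scatter), so compound 3 and compound 4 cannot be ranked. Among these compounds, this is the first change of this group with a size that can be read as a true number, and on this core it gives no measurable difference: a ring carrying fluorine and a ring carrying methyl, each with the same count of heavy atoms, read alike here. The earlier change of this group, on compound 2, gave only a limit of the assay and not a number: the limit of > 20000 nM in this assay, at which 1 of the 4 values shown sits.

On these data alone, it remains open whether 2-fluorophenyl would read the same on the core of compound 1, which lacks the fluoro carried by compound 3 and compound 4. Every group shown on this nitrogen is a substituted phenyl ring, so the effect of something quite different there, such as an amine, a carboxylic acid or a longer chain, also remains an open question.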